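The source may hold more compounds than are shown below. What is called first, only, known or untested is meant among the compounds shown, and "the series" means these compounds.

Two measured compounds share one core and differ only in the group on the amine nitrogen of the piperazine ring. Compound 1 `CC1(C)c2cc(Cl)ccc2C(=O)N1c1cncc(N2CCN(S(C)(=O)=O)CC2)c1` carries a methylsulfonyl there, and in an assay on cells for inhibition of cytochrome P450 11B2, mitochondrial (Homo sapiens), read by HTRF (a lower number here means a stronger inhibitor, a higher number a weaker inhibitor), compound 1 gives 2 nM. Compound 2 `CC(=O)N1CCN(c2cncc(N3C(=O)c4ccc(Cl)cc4C3(C)C)c2)CC1` carries an acetyl instead, and in this assay compound 2 gives 9 nM. Among the measured compounds shown here, that exchange is the only measured step, a 4.5-fold higher number from compound 1 to compound 2 (0.65 log units; beyond the scatter), so compound 2 holds the higher of the two numbers so far.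

Compound 3 `CC(=O)NCc1cncc(N2C(=O)c3ccc(Cl)cc3C2(C)C)c1` goes further: the whole ring is removed and replaced by a short chain, (acetamidomethyl in place of 4-acetylpiperazin-1-yl on an aromatic carbon), a change on an aromatic carbon of a six-membered aromatic ring with one nitrogen, two atoms from the ring nitrogen. For the measured compounds named here, no measured step swaps a ring for a chain at this place; the step from compound 1 to compound 2 only shows that the ring substituent matters modestly. The acetyl and its hydrogen-bond acceptor are kept, so a large loss is not expected, but a modest rise in the number is the more likely outcome, estimated as a 3.3-fold higher number from compound 2 to compound 3 (0.52 log units; beyond the scatter). In this assay compound 3 is therefore expected to give about 30 nM, within a range of 6 nM to 150 nM.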

Compound 3, half-maximal inhibitory concentration: 59 nM
Compound 3: middle estimate off by 2.0-fold (0.29 log units), on the low side, and the stated range covers the measured number.
By their numbers in this assay, from the lowest: compound 1; then compound 2; then compound 3.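

In this assay, among the compounds shown here, the exchange of the ring for the chain gives a 6.6-fold higher number from compound 2 to compound 3 (0.82 log units; beyond the scatter) and so shows, for the first time, that the whole group at this aromatic carbon matters, not only the cap on the piperazine nitrogen. Compound 3 remains an inhibitor without 4-acetylpiperazin-1-yl, so the six-membered non-aromatic ring is not required for activity, although acetamidomethyl is the weaker of these two groups here. The swap changes several things at once, removing the ring, reducing the size of the group and adding an amide hydrogen, and nothing available here explains the loss or separates these changes.

As far as these compounds go, it remains open whether a methylsulfonyl on the same short chain would give a lower number than the acetyl, as it does on the piperazine ring. Also open, from the compounds shown here alone, is how a longer chain, a free amine or a carboxylic acid at this position would compare, and whether replacing the amide hydrogen with a methyl group would change the number.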